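This account rests on a few compounds, and the source may have more. Where it says the series, first, only, none or still open, it means among the compounds named here.

Measured so far:
- compound 1, `Cc1ncnc2c1c(-c1cccs1)cn2[C@@H]1O[C@H](CO)[C@@H](O)[C@H]1O`: in an ADME assay on BJ cells (Homo sapiens), read by MTT assay, with a stated time of 72 h (a lower number here means a stronger inhibitor, a higher number a weaker inhibitor), compound 1 sits at a limit of the assay, > 100000 nM.
- compound 2, `COc1ncnc2c1c(-c1cccs1)cn2[C@@H]1O[C@H](CO)[C@@H](O)[C@H]1O`: compound 2 gives 62800 nM.
- compound 3, `CSc1ncnc2c1c(-c1cccs1)cn2[C@@H]1O[C@H](CO)[C@@H](O)[C@H]1O`: compound 3 gives 96900 nM.

Compound 1 stands at a limit of the assay and not at a number, which is where the limit of > 100000 nM in this assay, at which 1 of the 3 values shown sits, places it. The two measured steps that start from compound 1 both change only the methyl group on an aromatic carbon of the shared core: an at least 1.5-fold lower number from compound 1 to compound 2 (0.20 log units; that floor lies within the scatter) and an at least 1.0-fold lower number from compound 1 to compound 3 (0.01 log units; that floor lies within the scatter), and the remaining step, a 1.5-fold higher number from compound 2 to compound 3 (0.19 log units; within the scatter), is also within the scatter. None of the three compounds has any change at the position that matters for compound 4, `C#Cc1cn([C@@H]2O[C@H](CO)[C@@H](O)[C@H]2O)c2ncnc(C)c12`, whose difference from compound 1 is ethynyl in place of thiophen-2-yl on an aromatic carbon. Going by the values given here, no measured step therefore bears directly on this change, and what the measured compounds show is only that every value so far lies at the weak end of this assay, one of them at its limit.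

Among the compounds with values here, with no step to lean on, the expected step for compound 4 is none beyond the scatter, so that a number no higher from compound 1 to compound 4 (the limit leaves the size open) is the estimate. Compound 4 is accordingly expected to give about 100000 nM, within a range from 30000 nM to 300000 nM, with a fair chance that this assay again reports only a limit.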

Compound 4, half-maximal inhibitory concentration: 50 nM
Estimate against measurement, compound 4: 2000-fold (3.30 log units) above, outside the stated range (below it).
By their numbers in this assay, from the lowest: compound 4; then compounds 2 and 3 (each within the scatter of the next). At a limit, above all of these: compound 1.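

Ethynyl in place of thiophen-2-yl on this aromatic carbon of the five-membered ring gives, in this assay, an at least 2000-fold lower number from compound 1 to compound 4 (3.30 log units; beyond the scatter). This shows that the number in this assay can depend very strongly on this position, and that the group here can carry a compound from the weak end of the assay to a far lower value. The earlier compounds all kept thiophen-2-yl and differed only in the group where compound 1 carries methyl, with every step among them, or floor of a step, within the scatter, so they gave no sign of such sensitivity; compound 1 itself stands at a limit and not at a number, which leaves the full size of the new step unknown: the limit of > 100000 nM in this assay, at which 1 of the 4 values shown sits.

From the compounds shown here alone, it remains open whether the large step depends on the loss of thiophen-2-yl or on ethynyl itself, and how a nitrile, a bromine atom or a longer alkyne chain would read at this place. Also open, going by these compounds, is whether ethynyl would act in the same way with methoxy or methylsulfanyl in place of the methyl group on the shared core.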